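A few compounds are considered here, and "the series" means these few. Any claim that something is new, unique, unknown or untested is made for them only; others in the source may bear on it.

Measured so far in a functional assay on A549 cells (Homo sapiens) for inhibition, read by MTT assay, with a stated time of 72 h; on this read-out higher numbers stand for weaker inhibition and lower numbers for stronger inhibition:
Compound 1 `Cc1ccc2c(c1)/C(=N/NC(=S)N1CCN(c3ccccc3)CC1)C(=O)N2` gives 9880 nM.
Compound 2 `COc1ccc2c(c1)/C(=N/NC(=S)N1CCN(c3ccccc3)CC1)C(=O)N2` gives 7520 nM.
Compound 3 `O=C1Nc2ccc(F)cc2/C1=N/NC(=S)N1CCN(c2ccccc2)CC1` gives 20700 nM.

Compound 1 stands second highest of these three numbers. Its nearest neighbour is a step within the scatter: a 1.3-fold lower number from compound 1 to compound 2 (0.12 log units; within the scatter). Its furthest is a modest step beyond it: a 2.1-fold higher number from compound 1 to compound 3 (0.32 log units; beyond the scatter).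

Compound 4 `O=C1Nc2ccc([N+](=O)[O-])cc2/C1=N/NC(=S)N1CCN(c2ccccc2)CC1` has not been measured. It differs from compound 1 in one place: nitro in place of methyl on an aromatic carbon. Both measured steps bear on this change, since each also swaps the methyl on that aromatic carbon for another group, and they ranged from no change to a modest rise in this assay. A similar outcome, from none beyond the scatter to a modest weakening, is expected here. Compound 4 is therefore estimated at 13000 nM, with a range of 5000 nM to 35000 nM. That amounts to an expected 1.3-fold higher number from compound 1 to compound 4 (0.12 log units; within the scatter).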

Compound 4, half-maximal inhibitory concentration: 17900 nM
For compound 4 the middle estimate is 1.4-fold (0.14 log units) below the measured one; measured number inside the range.
By their numbers in this assay, from the lowest: compounds 2, 1, 4 and 3 (each within the scatter of the next, the first and the last beyond it).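

In this assay, nitro on this aromatic carbon gives no change beyond the scatter against methyl (a 1.8-fold higher number from compound 1 to compound 4 (0.26 log units; within the scatter)) or against fluoro (a 1.2-fold lower number from compound 3 to compound 4 (0.06 log units; within the scatter)). It stands apart only from methoxy, with a modest weakening (a 2.4-fold higher number from compound 2 to compound 4 (0.38 log units; beyond the scatter)). So a group as different in size from methyl as nitro still leaves the number close to those of compound 1 and compound 3, and no measurement here offers a reason for these steps.

Going by these compounds, whether an amine, a carboxylic acid or a longer chain on this carbon would shift the number further remains open. So does the effect of changing any other part of the shared core.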